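Methyl on the amide nitrogen: outlook for compound 4

The source may report more compounds than this note shows. Statements on the series, on what has been measured and on what is new or still open speak of the compounds shown alone.

Values in a functional assay on the whole organism for antagonist activity, with Mus musculus as the target (a lower number here means that less compound is needed, a higher number that more compound is needed for the effect), each one a limit:
compound 1 `CC(=O)N(C)C(C)C#CCn1ccnc1` gives > 100 mg/kg (limit)
compound 2 `CC(=O)NCC#CCn1ccnc1` gives > 100 mg/kg (limit)
compound 3 `CC(=O)NCC#CCn1cncc1C` gives > 100 mg/kg (limit)

Compound 2 stands only at a limit (> 100 mg/kg) and has no number to start from. Compound 4 `CC(=O)N(C)CC#CCn1ccnc1` differs from compound 2 by methyl in place of hydrogen on an amide-type nitrogen. Going by the values given here, the one measured step (a step that the two limits leave unreadable from compound 2 to compound 3) places a methyl on an aromatic carbon and gives no size. All three compounds share one limit (the limit of > 100 mg/kg in this assay, at which 3 of the 3 values shown sit). In this assay no readable step and no direction can be foreseen, and the expected step (a step that the limit leaves unreadable from compound 2 to compound 4) stays within the scatter. Estimated for compound 4: 150 mg/kg (range 70 mg/kg to 300 mg/kg).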

Compound 4, dose for half-maximal effect: > 100 mg/kg
Compound 4: a limit, no number; the forecaster's own chance of this, stated with the estimate: 85%; the middle value lies beyond the limit too.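

In this assay, neither compound 1 nor compound 2 gives a readable step to compound 4: the limit of > 100 mg/kg in this assay, at which 4 of the 4 values shown sit.

The compounds shown leave open what effect, if any, methyl in place of hydrogen on the amide-type nitrogen has on the dose needed.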